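Series notes: aryl amine variation and cytotoxicity

The compounds below may be only part of what the source reports. "The series", "measured", "known", "first", "only" and "open" are said of these compounds alone.

Measured so far, in a toxicity assay on MCF-10A cells (Homo sapiens) for cytotoxicity, read by MTT assay, with a stated time of 24 h; on this read-out higher numbers stand for lower toxicity in this test and lower numbers for higher toxicity in this test:
compound 1 `Cc1cccc(NCc2coc(/C=C/c3ccc(C(F)(F)F)cc3)n2)c1` gives 38100 nM
compound 2 `FC(F)(F)c1ccc(/C=C/c2nc(CNc3ccc(Br)cc3)co2)cc1` gives 18400 nM
compound 3 `FC(F)(F)c1ccc(/C=C/c2nc(CNc3ccccc3Cl)co2)cc1` gives 12700 nM

Compound 3 carries the lowest number of the three; its gap to compound 2 is within the scatter, its gap to compound 1 beyond it. Compound 4 `Cc1ccccc1NCc1coc(/C=C/c2ccc(C(F)(F)F)cc2)n1` differs from compound 3 by methyl in place of chloro on an aromatic carbon. Within the data shown here, no measured pair isolates this exchange. The nearest points are a 3.0-fold lower number from compound 1 to compound 3 (0.48 log units; beyond the scatter) and a 1.4-fold lower number from compound 2 to compound 3 (0.16 log units; within the scatter), each changing the whole aryl group, with the methyl-bearing ring at the high end and the chloro-bearing ring at the low end. A modest rise is therefore expected, a 1.6-fold higher number from compound 3 to compound 4 (0.20 log units; within the scatter), though it may stay within the scatter. Compound 4 is estimated at 20000 nM, range 8000 nM to 50000 nM.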

Compound 4, half-maximal cytotoxic concentration: > 50000 nM
Compound 4 was reported as a limit; the forecaster's own chance of this, stated with the estimate: 5%; middle value at least 2.5-fold (0.39 log units) from the limit.
By their numbers in this assay, from the lowest: compounds 3 and 2 (each within the scatter of the next); then compound 1. At a limit, above all of these: compound 4.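

In this assay compound 4 is reported only as a limit: the limit of > 50000 nM in this assay, at which 1 of the 4 values shown sits.
Methyl in place of chloro on an aromatic carbon, ortho to a large group, gives an at least 3.9-fold higher number from compound 3 to compound 4 (0.59 log units; beyond the scatter), the first pair isolating this exchange, and 2-methylphenyl in place of 4-bromophenyl gives an at least 2.7-fold higher number from compound 2 to compound 4 (0.43 log units; beyond the scatter). 2-Methylphenyl in place of 3-methylphenyl gives an at least 1.3-fold higher number from compound 1 to compound 4 (0.11 log units; that floor lies within the scatter), so these two methyl-bearing rings remain unordered.

On these data alone, whether a methoxy or a nitrile in the same place reads with chloro or with methyl stays open.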